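A few compounds are considered here, and "the series" means these few. Any claim that something is new, unique, unknown or untested is made for them only; others in the source may bear on it.

Compound 2 `Cn1nnnc1SCC(=O)Nc1ccc(-c2nc(-c3ccccc3)c(-c3ccccc3)n2C)cc1` stands highest of the two numbers in a functional assay on HT-29 cells (Homo sapiens) for cytotoxicity, read by MTT assay, with a stated time of 24 h, tested at 1.6 ug/mL (on this read-out higher numbers stand for a stronger effect at the one concentration tested and lower numbers for a weaker effect), giving 49.8%. Compound 1 `Cc1ccc2oc(SCC(=O)Nc3ccc(-c4nc(-c5ccccc5)c(-c5ccccc5)n4C)cc3)nc2c1` gives 15.5%, and the step of a number 34.3 percentage points higher from compound 1 to compound 2 (beyond the scatter) shows that swapping the group on the sulfur can move the number a great deal. Compound 3 `CN1CCN(CC(=O)Nc2ccc(-c3nc(-c4ccccc4)c(-c4ccccc4)n3C)cc2)CC1` differs from compound 2 in that (4-methylpiperazin-1-yl in place of (1-methyl-1H-tetrazol-5-yl)sulfanyl on a saturated chain carbon bound to a carbonyl carbon). For the measured compounds named here, no measured step covers this change, since both measured compounds keep the sulfur link; the one measured step only shows that this part of the molecule can shift the read-out strongly. A drop of a number 19.8 percentage points lower from compound 2 to compound 3 (beyond the scatter) is expected, with wide uncertainty. Compound 3 is estimated at 30%, in a range from 10% to 55%.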

Compound 3, a percentage reported as activity, at one concentration (the size of the read-out at that concentration, not a potency): 27.4%
For compound 3 the middle estimate is 2.6 percentage points above the measured one; measured number inside the range.
By their numbers in this assay, from the lowest: compound 1; then compound 3; then compound 2.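

Compound 3 shows that the sulfur link on the saturated chain carbon can be replaced while a read-out remains in this assay, with a number 22.4 percentage points lower from compound 2 to compound 3 (beyond the scatter) and a number 11.9 percentage points higher from compound 1 to compound 3 (beyond the scatter). The 4-methylpiperazin-1-yl group ranks under one sulfur-linked group and over the other, so presence of sulfur alone does not set the order among these three compounds. Nothing available explains these shifts. Going by these compounds, whether a morpholine ring or an open-chain dimethylamino group on this carbon would read higher or lower remains open. The single tested concentration also leaves potency unknown.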